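This account rests on a few compounds, and the source may have more. Where it says the series, first, only, none or still open, it means among the compounds named here.

In a functional assay on HeLa cells (Homo sapiens) for inhibition, read by MTT assay, with a stated time of 48 h (on this read-out lower numbers stand for stronger inhibition and higher numbers for weaker inhibition), compound 1 `O=S(=O)(c1ccccc1)c1c(OCCCCCCO)no[n+]1[O-]` stands as "not determined" (no result reported) and offers no number to compare. Compound 2 `O=C(COCCOc1no[n+]([O-])c1S(=O)(=O)c1ccccc1)NO` gives 6690 nM and compound 3 `CC(C)(COc1no[n+]([O-])c1S(=O)(=O)c1ccccc1)C(=O)NO` gives 6360 nM on this read-out. These two numbers lie within the scatter of each other, so compound 3 cannot be told apart from compound 2. Compound 4 `O=C(/C=C/COc1no[n+]([O-])c1S(=O)(=O)c1ccccc1)NO` differs from compound 3 by 2-(hydroxycarbamoyl)ethenyl in place of 1-(hydroxycarbamoyl)-1-methylethyl on a saturated chain carbon bound to an oxygen on an aromatic ring or in words 2-(hydroxycarbamoyl)ethenyl in place of 1-(hydroxycarbamoyl)-1-methylethyl on a saturated chain carbon bound to an oxygen on an aromatic ring. For the measured compounds named here, the one measured step bearing on this, a 1.1-fold lower number from compound 2 to compound 3 (0.02 log units; within the scatter), altered the same chain and stayed within the scatter. No step beyond the scatter is therefore expected in this assay here. Compound 4 is expected near 5000 nM with an estimated range from 1500 nM to 15000 nM around that figure. This estimate amounts to an expected 1.3-fold lower number from compound 3 to compound 4 (0.10 log units; within the scatter) and no more.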

Compound 4, half-maximal inhibitory concentration: 8740 nM
Compound 4: the middle estimate sits 1.7-fold (0.24 log units) below what was measured; the range from low to high includes it.
By their numbers in this assay, from the lowest: compounds 3, 2 and 4 (each within the scatter of the next).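

In this assay, 2-(hydroxycarbamoyl)ethenyl in place of 1-(hydroxycarbamoyl)-1-methylethyl gives a 1.4-fold higher number from compound 3 to compound 4 (0.14 log units; within the scatter) and the same group in place of ((hydroxycarbamoyl)methoxy)methyl gives a 1.3-fold higher number from compound 2 to compound 4 (0.12 log units; within the scatter). On a saturated chain carbon bound to an oxygen on an aromatic ring, three different chains ending in the hydroxycarbamoyl group, one with a carbon-carbon double bond, thus cannot be told apart. Nothing available explains this result. Still open is whether a carboxylic acid in place of the hydroxycarbamoyl group, or a longer chain carrying it, would stay within the scatter of these compounds in this assay.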